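The compounds below may be only part of what the source reports. "The series", "measured", "known", "first", "only" and "open" are said of these compounds alone.

Going by the values given here, the three compounds measured so far all share a nitro-substituted chlorobenzamide joined to a methylphenyl ring that carries a fused bicyclic group; what varies is the bicyclic group and whether a hydroxy group sits on the middle ring. Compound 1 is `Cc1cc(NC(=O)c2cc([N+](=O)[O-])ccc2Cl)cc(-c2nc3ccccc3o2)c1O`, compound 2 is `Cc1cc(NC(=O)c2cc([N+](=O)[O-])ccc2Cl)cc(-c2nc3ccccc3s2)c1O` and compound 3 is `Cc1ccc(-c2nc3ccccc3s2)cc1NC(=O)c1cc([N+](=O)[O-])ccc1Cl`. How the core of compound 2 differs from the core of compound 3 is not broken down here.

In an ADME assay on Raji cells (Homo sapiens) for cytotoxicity, with a stated time of 72 h (on this read-out lower numbers stand for an effect already at smaller amounts and higher numbers for an effect only at larger amounts of compound), compound 1 gives > 25000 nM, which is a limit of the assay and not a number. Compound 2 gives > 25000 nM in this assay, again a limit. Compound 3 gives > 14000 nM in this assay, also a limit.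

The change 1,3-benzoxazol-2-yl in place of 1,3-benzothiazol-2-yl on an aromatic carbon gives the step that the two limits leave unreadable from compound 2 to compound 1; its size cannot be read since both ends rest on (the limit of > 25000 nM in this assay, at which 2 of the 3 values shown sit).

Compound 4, `Cc1ccc(-c2nc3ccccc3o2)cc1NC(=O)c1cc([N+](=O)[O-])ccc1Cl`, is still to be measured. It carries the change (1,3-benzoxazol-2-yl in place of 1,3-benzothiazol-2-yl on an aromatic carbon), the same kind of change as that from compound 2 to compound 1, though the place differs: in compound 2 the carbon is ortho to a hydroxy group and meta to a methyl group, whereas in compound 3 it is para to a methyl group and no hydroxy group is present.

For compound 4 a step that the limit leaves unreadable from compound 3 to compound 4 is expected in this assay, resting on compound 3 sitting at the limit of > 14000 nM in this assay, at which 1 of the 3 values shown sits, and on the unreadable step that the two limits leave unreadable from compound 2 to compound 1. The estimate for compound 4 is therefore 25000 nM in this assay, with a large chance that only a limit is reported.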

Compound 4, half-maximal effective concentration: > 14000 nM
Compound 4 was reported as a limit; the forecaster's own chance of this, stated with the estimate: 80%; the middle value does not contradict the limit.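

Compound 3 and compound 4 both sit at the same limit of the assay, which is not a number, so no step can be read between them: the limit of > 14000 nM in this assay, at which 2 of the 4 values shown sit.

The compounds shown leave open whether 1,3-benzoxazol-2-yl in place of 1,3-benzothiazol-2-yl changes the result in this assay at all, and at what concentration any of the four compounds would show an effect.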